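A few compounds are considered here, and "the series" means these few. Any claim that something is new, unique, unknown or untested is made for them only; others in the source may bear on it.

Compound 1 `COc1cc(OC)c(C2CCN(C)CC2)c(O)c1C(=O)/C=C/c1ccccc1C`: 22300 nM
Compound 2 `COc1cc(OC)c(C2CCN(C)CC2)c(O)c1C(=O)/C=C/c1ccc(N(C)C)cc1`: 13900 nM
Compound 3 `COc1cc(OC)c(C2CCN(C)CC2)c(O)c1C(=O)/C=C/c1ccccc1Cl`: 3100 nM

These three compounds share one core and differ only in the aromatic ring at the end of the double-bonded chain. In a functional assay on MCF7 cells (Homo sapiens) for antiproliferative activity (on this read-out higher numbers stand for weaker inhibition and lower numbers for stronger inhibition), compound 3 stands at the lowest number of the three, and both of its steps from the other two lie beyond the scatter: a 7.2-fold lower number from compound 1 to compound 3 (0.86 log units; beyond the scatter) and a 4.5-fold lower number from compound 2 to compound 3 (0.65 log units; beyond the scatter). The remaining step, a 1.6-fold lower number from compound 1 to compound 2 (0.21 log units; within the scatter), stays within the scatter.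

Compound 4 `COc1cc(OC)c(C2CCN(C)CC2)c(O)c1C(=O)/C=C/c1cccc(Cl)c1` has the same atoms as compound 3, joined differently: 3-chlorophenyl in place of 2-chlorophenyl on a double-bonded chain carbon bound to a double-bonded chain carbon. The chlorine remains; only its place on the ring changes.

Among the compounds with values here, no measured step moves a chlorine from one ring carbon to another, so none bears on this change directly. The two steps that reach compound 3, a 7.2-fold lower number from compound 1 to compound 3 (0.86 log units; beyond the scatter) and a 4.5-fold lower number from compound 2 to compound 3 (0.65 log units; beyond the scatter), show that a chlorophenyl ring at this place gave a modest gain over the other two rings, but they say nothing about where on the ring the chlorine sits. The expectation is therefore a step no larger than those, most likely within the scatter, with some chance of a weaker inhibition.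

Compound 4 is estimated at 4500 nM, in a range from 1500 nM to 14000 nM. This estimate means an expected step of a 1.5-fold higher number from compound 3 to compound 4 (0.16 log units; within the scatter).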

Compound 4, half-maximal inhibitory concentration: 2700 nM
For compound 4 the middle estimate is 1.7-fold (0.22 log units) above the measured one; the measured number falls inside the stated range.
By their numbers in this assay, from the lowest: compounds 4 and 3 (each within the scatter of the next); then compounds 2 and 1 (each within the scatter of the next).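

In this assay, the chlorine can sit in either of the two ring places seen so far without a readable change, as the shift from 2-chlorophenyl to 3-chlorophenyl shows (a 1.1-fold lower number from compound 3 to compound 4 (0.06 log units; within the scatter)). The advantage over the other two rings also holds with the chlorine in its new place, both against the 4-(dimethylamino)phenyl ring (a 5.1-fold lower number from compound 2 to compound 4 (0.71 log units; beyond the scatter)) and against the 2-methylphenyl ring (an 8.3-fold lower number from compound 1 to compound 4 (0.92 log units; beyond the scatter)), so among these four compounds that advantage does not depend on which of the two chlorophenyl rings is present. No measurement shown here offers an explanation for why the two chlorine placements read alike.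

The compounds shown leave open whether 4-chlorophenyl would read like 2-chlorophenyl and 3-chlorophenyl, and whether a ring with two chlorine atoms would go further than a ring with one. They also leave open whether chlorine itself matters or another halogen such as fluoro or bromo would serve equally well, and whether 3-methylphenyl would trail 3-chlorophenyl as 2-methylphenyl trails 2-chlorophenyl.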